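Removing the Sulfur Group from Compound 2

This account rests on a few compounds, and the source may have more. Where it says the series, first, only, none or still open, it means among the compounds named here.

- compound 1 `CC(C)c1n[nH]c2c(NCc3ccc(-c4ccccn4)cc3)nc(SC(CO)C(C)C)nc12` gives 980 nM
- compound 2 `CC(C)c1n[nH]c2c(NCc3ccc(-c4ccccn4)cc3)nc(SCCNC(N)=O)nc12` gives 240 nM

In a functional assay on HT cells (Homo sapiens) for antiproliferative activity, read by fluorescence, with a stated time of 72 h (on this read-out lower numbers stand for stronger inhibition of growth and higher numbers for weaker inhibition of growth), compound 2 holds the lower of the two numbers (240 nM) and so shows the stronger inhibition of growth. The next structure is compound 3 `CC(C)c1n[nH]c2c(NCc3ccc(-c4ccccn4)cc3)nc(S)nc12`, which has hydrogen in place of 2-ureidoethyl on a sulfur. Among the measured compounds shown here, only one measured step bears on this change, because it also swaps the group on that sulfur (a 4.1-fold lower number from compound 1 to compound 2 (0.61 log units; beyond the scatter)) and it is modest in size. For the measured compounds named here, no measured compound has a bare sulfanyl group, so that step is a thin guide and the direction is a judgement rather than a finding. A step of similar modest size is expected in this assay, towards a higher number, which would mean weaker inhibition of growth. The expected change is a 2.9-fold higher number from compound 2 to compound 3 (0.46 log units; beyond the scatter) in this estimate. Compound 3 is estimated at 700 nM with an expected range from 200 nM to 2500 nM as its limits.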

Compound 3, concentration for 50% growth inhibition: 2760 nM
Beside the measured number, compound 3's estimate is 3.9-fold (0.60 log units) below it, outside the stated range (above it).
By their numbers in this assay, from the lowest: compound 2; then compound 1; then compound 3.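

In this assay, the bare sulfanyl group ranks last of the three, with a 12-fold higher number from compound 2 to compound 3 (1.06 log units; beyond the scatter) and a 2.8-fold higher number from compound 1 to compound 3 (0.45 log units; beyond the scatter). Among the compounds shown here, this gives the position a baseline that the earlier pair lacked: that pair showed only that one group on the sulfur gave a lower number than another, whereas now both the 2-ureidoethyl and the 1-(hydroxymethyl)-2-methylpropyl groups give lower numbers than hydrogen, and the 2-ureidoethyl group gives the larger drop. Nothing in the data explains why removing either group weakens growth inhibition.

The compounds shown leave open which part of the 2-ureidoethyl group accounts for its lower number, since a plain ethyl group on the sulfur or an ethyl chain ending in an amine would help separate the contribution of the chain from that of the urea at its end. From the compounds shown here alone, it also remains open how far this position can be pushed, for example whether a longer chain or one ending in a carboxylic acid would give a lower or a higher number than compound 2.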